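This account rests on a few compounds, and the source may have more. Where it says the series, first, only, none or still open, it means among the compounds named here.

Compound 1 `Cn1nc(C(=O)O)c2c1CCN(C(=O)Nc1ccc(Cl)cc1)C2`: in an assay on cells for inhibition of Pendrin (Mus musculus), read by fluorescence, with a stated time of 10 min (a lower number here means a stronger inhibitor, a higher number a weaker inhibitor), compound 1 gives > 10000 nM, which is a limit of the assay rather than a number.
Compound 2 `Cn1nc(COc2cc(F)cc(F)c2)c2c1CCN(C(=O)Nc1ccc(Br)cc1)C2`: in this assay compound 2 gives 3300 nM.
Compound 3 `Cn1nc(COc2cc(F)cc(F)c2)c2c1CCN(C(=O)NC(=O)c1ccccc1)C2`: in this assay compound 3 gives > 10000 nM, again a limit of the assay.

Compound 2 is therefore the only one of the three with a measured number; the other two sit at the limit of > 10000 nM in this assay, at which 2 of the 3 values shown sit. For the measured compounds named here, only one measured step compares two compounds that differ in a single place: an at least 3.0-fold higher number from compound 2 to compound 3 (0.48 log units; beyond the scatter), where a benzoyl replaces the 4-bromophenyl on the urea nitrogen and the inhibition falls past the limit.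

Compound 4 `Cn1nc(COc2cc(F)cc(F)c2)c2c1CCN(S(C)(=O)=O)C2` removes more than that step did: methylsulfonyl in place of (4-bromophenyl)carbamoyl on an amine nitrogen in a ring. The whole (4-bromophenyl)carbamoyl group leaves, and a small methylsulfonyl takes its place on the ring nitrogen. Because an at least 3.0-fold higher number from compound 2 to compound 3 (0.48 log units; beyond the scatter) already carried a milder change past the limit, the inhibition of compound 4 is expected to weaken at least as much, most likely beyond what the assay can report.

Compound 4 is therefore expected to give about 15000 nM in this assay, within an expected range from 4000 nM to 60000 nM. The expected step from compound 2 to compound 4 is a 4.5-fold higher number from compound 2 to compound 4 (0.66 log units; beyond the scatter).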

Compound 4, half-maximal inhibitory concentration: > 10000 nM
Compound 4: only a limit was reported; the forecaster's own chance of this, stated with the estimate: 70%; the middle value lies beyond the limit too.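

In this assay, replacing the whole (4-bromophenyl)carbamoyl group on the amine nitrogen in the ring with methylsulfonyl gives an at least 3.0-fold higher number from compound 2 to compound 4 (0.48 log units; beyond the scatter), and this size is only a floor, since the value of compound 4 is a limit of the assay and not a number. The earlier step changed only the 4-bromophenyl part and kept the rest of the urea, whereas this change removes the aromatic ring and the hydrogen-bond donor together, so a second, quite different group at this nitrogen also fails to give a measurable number. Compound 2 therefore remains the only compound with a measured value, and the others collect at one boundary: the limit of > 10000 nM in this assay, at which 3 of the 4 values shown sit.

The compounds shown cannot separate the loss of the aromatic ring from the loss of the hydrogen-bond donor, and a 4-bromobenzoyl or a (4-bromophenyl)sulfonyl group on this nitrogen would be the natural way to pull the two apart. From the compounds shown here alone, how far compound 3 and compound 4 lie beyond the limit also stays open, so the two replacements cannot be ranked against each other.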